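Dichlorophenyl for methylphenyl on a sulfonamide scaffold

The source may report more compounds than this note shows. Statements on the series, on what has been measured and on what is new or still open speak of the compounds shown alone.

Measured compounds:
compound 1 `Cc1ccc(C2C(C#N)=C(N)N(c3ccc(S(N)(=O)=O)cc3)C3=C2CCCC3)cc1`, 20%
compound 2 `N#CC1=C(N)N(c2ccc(S(N)(=O)=O)cc2)C2=C(CCCC2)C1/C=C/c1ccccc1`, 50%

Compound 1 `Cc1ccc(C2C(C#N)=C(N)N(c3ccc(S(N)(=O)=O)cc3)C3=C2CCCC3)cc1` is the weaker of the two measured compounds in a functional assay on Ehrlich cells (Mus musculus) for cytotoxicity, read by trypan blue exclusion, with a stated time of 2 h, tested at 10 ug/mL (a lower number here means a weaker effect, a higher number a stronger effect of the compound at the concentration tested), where compound 1 gives 20%. Its nearest neighbour is compound 2 `N#CC1=C(N)N(c2ccc(S(N)(=O)=O)cc2)C2=C(CCCC2)C1/C=C/c1ccccc1`, which in this assay gives 50%. Among the compounds with values here, the one measured step, a number 30 percentage points higher from compound 1 to compound 2 (beyond the scatter), shows a modest rise beyond the scatter when the 4-methylphenyl on the saturated ring carbon is exchanged.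

Compound 3 `N#CC1=C(N)N(c2ccc(S(N)(=O)=O)cc2)C2=C(CCCC2)C1c1ccc(Cl)c(Cl)c1` carries a different exchange at the same place: 3,4-dichlorophenyl in place of 4-methylphenyl on a saturated ring carbon. Within the data shown here, no measured pair exercises this particular change, so the only guide is the single step from compound 1 to compound 2, which exchanged the same group and gave a modest rise. A step of similar direction but uncertain size is therefore expected, a number 12 percentage points higher from compound 1 to compound 3 (beyond the scatter), and for compound 3 the expected value in this assay is 32%, within 12% to 55%.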

Compound 3, a percentage reported as activity, at one concentration (the size of the read-out at that concentration, not a potency): 1%
The estimate for compound 3 lay 31 percentage points above the measured number; measured number below the stated range.
By their numbers in this assay, from the lowest: compound 3; then compound 1; then compound 2.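

In this assay, within the data shown here, the earlier compounds showed this saturated ring carbon only as a place where the read-out rises, but it can also fall: 3,4-dichlorophenyl gives a number 19 percentage points lower from compound 1 to compound 3 (beyond the scatter) and, set against 2-phenylethenyl, it gives a number 49 percentage points lower from compound 2 to compound 3 (beyond the scatter) on the same core. Compound 1 and compound 3 each carry one six-membered aromatic ring of carbon only at this place, so that ring alone does not fix the read-out; the substituents on it matter here. Nothing measured here explains why the dichlorinated ring falls so low. On these data alone, whether a single chlorine on the phenyl ring would give the same drop remains open. So does the place in this order of a methoxy group, an amine or a carboxylic acid on that ring, or of a longer chain in place of 2-phenylethenyl.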